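Exchanging One Side Chain on a Shared Core

The compounds below may be only part of what the source reports. "The series", "measured", "known", "first", "only" and "open" are said of these compounds alone.

In an ADME assay on HeLa cells (Homo sapiens) for cytotoxicity, read by MTT assay (a lower number here means a stronger inhibitor, a higher number a weaker inhibitor), compound 1 `COC(=O)[C@@H]1CCCN1C(=O)CCC(=O)Oc1ccc(C[C@H]2C(=O)OC[C@@H]2Cc2ccc(OC)c(OC)c2)cc1OC` gives 145000 nM and compound 2 `CCN(CC)C(=O)CCC(=O)Oc1ccc(C[C@H]2C(=O)OC[C@@H]2Cc2ccc(OC)c(OC)c2)cc1OC` gives 213000 nM, so the two values lie within the scatter of each other. Compound 3 `COc1ccc(C[C@H]2COC(=O)[C@@H]2Cc2ccc(OCC(=O)N3CCCCC3)c(OC)c2)cc1OC` differs from compound 2 by a group of 9 heavy atoms (7 carbon, 1 nitrogen, 1 oxygen; one six-membered non-aromatic ring with 1 hetero atom) in place of a group of 11 heavy atoms (8 carbon, 1 nitrogen, 2 oxygen; no ring), on an oxygen on an aromatic ring, and the entering group is ((piperidin-1-yl)carbonyl)methyl. Going by the values given here, the only measured guide is the step of a 1.5-fold higher number from compound 1 to compound 2 (0.17 log units; within the scatter), which is a different change and stayed within the scatter. No step beyond the scatter is therefore expected in this assay, and the estimated step is a 1.4-fold lower number from compound 2 to compound 3 (0.15 log units; within the scatter). For compound 3 the estimate is 150000 nM, with an expected range from 60000 nM to 400000 nM.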

Compound 3, half-maximal inhibitory concentration: 293000 nM
Compound 3: the middle estimate sits 2.0-fold (0.29 log units) below what was measured; the measured number falls inside the stated range.
By their numbers in this assay, from the lowest: compounds 1, 2 and 3 (each within the scatter of the next, the first and the last beyond it).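

The earlier pair changed only the group on a carbonyl carbon, whereas this change replaces the whole group on an oxygen on an aromatic ring. In this assay, bringing in ((piperidin-1-yl)carbonyl)methyl, with its six-membered non-aromatic ring, gives a 1.4-fold higher number from compound 2 to compound 3 (0.14 log units; within the scatter) and so does not separate the two compounds. No supporting measurement bears on this result.

The compounds shown cover only neutral groups at this oxygen. Going by these compounds, whether a carboxylic acid, a primary amine or a longer chain there would produce a step beyond the scatter remains open.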